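This account rests on a few compounds, and the source may have more. Where it says the series, first, only, none or still open, it means among the compounds named here.

Measured in a functional assay on CHO cells for agonist activity at adenosine receptor A1 (Homo sapiens), read by fluorescence and ERK phosphorylation, with stated times of 30 min and 1.5 h, tested at 10 uM; a higher number here means a stronger effect of the compound at the concentration tested, a lower number a weaker effect:
compound 1 `Nc1scc(-c2cccc(F)c2)c1C(=O)c1ccccc1` gives 52%
compound 2 `Nc1scc(-c2ccc(F)cc2)c1C(=O)c1ccccc1` gives 60%
compound 3 `Nc1scc(-c2cccc(Br)c2)c1C(=O)c1ccccc1` gives 76%

Compound 2 stands second highest of the three numbers; its nearest neighbour is compound 1, a number 8 percentage points higher from compound 1 to compound 2 (within the scatter), and the furthest is compound 3, a number 16 percentage points higher from compound 2 to compound 3 (beyond the scatter). Compound 4 `COc1ccc(-c2csc(N)c2C(=O)c2ccccc2)cc1` is not yet measured. It differs from compound 2 by methoxy in place of fluoro on an aromatic carbon. The measured steps that exchange one group for another on an aromatic carbon are a number 24 percentage points higher from compound 1 to compound 3 (beyond the scatter) and a number 16 percentage points higher from compound 2 to compound 3 (beyond the scatter), both modest. Within the data shown here, no measured step exchanges fluoro for methoxy, so the direction of this change is not fixed by the data. A step of at most modest size, or none beyond the scatter, is therefore expected: a number 2 percentage points higher from compound 2 to compound 4 (within the scatter). For compound 4 in this assay the estimate is 62%, with a range from 45% to 80%.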

Compound 4, a percentage reported as activity, at one concentration (the size of the read-out at that concentration, not a potency): 52%
Compound 4: middle estimate off by 10 percentage points, on the high side; measured number inside the range.
By their numbers in this assay, from the lowest: compounds 1, 4 and 2 (each within the scatter of the next); then compound 3.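

In this assay, methoxy in place of fluoro on an aromatic carbon, para to a large group, gives a number 8 percentage points lower from compound 2 to compound 4 (within the scatter). Among these compounds, until now this series carried only fluoro or bromo on that ring, so this is the first sign that a group with a hydrogen-bond acceptor can stand at this position without a change beyond the scatter. No measurement available here bears on why the number falls where it does.

Open, on these data alone, is how an amine or a carboxylic acid would behave at this position. Among the compounds shown here, also open is whether bromo, seen only in compound 3, would read the same here.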